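Fluoro for Methoxy on the Urea-Side Phenyl Ring

The source may report more compounds than this note shows. Statements on the series, on what has been measured and on what is new or still open speak of the compounds shown alone.

Measured so far:
compound 1, `COc1ccc(NC(=O)Nc2nnc(Sc3ncnc4scc(-c5ccncc5)c34)s2)cc1`: > 100000 nM
compound 2, `O=C(Nc1ccc(F)cc1)Nc1nnc(Sc2ncnc3scc(-c4ccncc4)c23)s1`: 18900 nM
compound 3, `COc1cccc(NC(=O)Nc2nnc(Sc3ncnc4scc(-c5ccncc5)c34)s2)c1`: 56900 nM

In a functional assay on T47D cells (Homo sapiens) for antiproliferative activity, read by MTT assay, with a stated time of 48 h (on this read-out higher numbers stand for weaker inhibition and lower numbers for stronger inhibition), compound 1 gives > 100000 nM, which is a limit of the assay rather than a number. Compound 2 gives 18900 nM and compound 3 gives 56900 nM. Compounds 1 and 3 differ only in how the same atoms are joined: 3-methoxyphenyl in place of 4-methoxyphenyl on an amide-type nitrogen, which gave an at least 1.7-fold lower number from compound 1 to compound 3 (0.24 log units; that floor lies within the scatter). The change from compound 1 to compound 2 is fluoro in place of methoxy on an aromatic carbon, and it gave an at least 5.2-fold lower number from compound 1 to compound 2 (0.72 log units; beyond the scatter).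

Compound 4, `O=C(Nc1cccc(F)c1)Nc1nnc(Sc2ncnc3scc(-c4ccncc4)c23)s1`, has not yet been measured. It differs from compound 3 by fluoro in place of methoxy on an aromatic carbon. This is the same kind of change as before, though here the fluoro sits meta to a large group, whereas in compound 2 it sits para to a large group. Because the earlier swap gave an at least 5.2-fold lower number from compound 1 to compound 2 (0.72 log units; beyond the scatter) starting from a limit, a smaller step is expected here, estimated as a 2.8-fold lower number from compound 3 to compound 4 (0.45 log units; beyond the scatter). Compound 4 is therefore expected to reach about 20000 nM in this assay, plausibly between 6000 nM and 60000 nM.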

Compound 4, half-maximal inhibitory concentration: 16700 nM
Compound 4: the middle estimate sits 1.2-fold (0.08 log units) above what was measured; the range from low to high includes it.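

Fluoro in place of methoxy lowers the number both from the 4-methoxyphenyl compound and from the 3-methoxyphenyl compound, so the direction of the change carries over between these two cores: the same change on two cores in this assay, an at least 5.2-fold lower number (0.72 log units; beyond the scatter) from compound 1 to compound 2 and a 3.4-fold lower number (0.53 log units; beyond the scatter) from compound 3 to compound 4; the limit leaves it open whether they differ. Compound 1 gives > 100000 nM, which is a limit of the assay and not a number, so the size of the change cannot be shown to carry over: the limit of > 100000 nM in this assay, at which 1 of the 4 values shown sits. The new swap gives a 3.4-fold lower number from compound 3 to compound 4 (0.53 log units; beyond the scatter) and the wider change gives an at least 5.9-fold lower number from compound 1 to compound 4 (0.77 log units; beyond the scatter) while moving the fluoro gives a 1.1-fold lower number from compound 2 to compound 4 (0.05 log units; within the scatter) so the two fluoro compounds cannot be told apart, and two cases set no rule for other cores.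

The compounds shown leave open whether the swap behaves the same way when a chloro, nitrile or amine group stands on that phenyl ring.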